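The source may hold more compounds than are shown below. What is called first, only, known or untested is meant among the compounds shown, and "the series" means these compounds.

Of the compounds shown here, three of a shared core have been measured in a functional assay on ME-180 cells (Homo sapiens) for cytotoxicity, read by MTT assay, with a stated time of 72 h; on this read-out lower numbers stand for stronger inhibition and higher numbers for weaker inhibition. Compound 1 `COc1ccc(C(=O)c2cc(OC)c(OC)c(OC)c2)cc1NC(=O)/C=C/c1ccc(F)cc1` gives 300 nM, compound 2 `COc1cc(/C=C/C(=O)Nc2cc(C(=O)c3cc(OC)c(OC)c(OC)c3)ccc2OC)ccc1F` gives 15500 nM, and compound 3 `COc1ccc(/C=C/C(=O)Nc2cc(C(=O)c3cc(OC)c(OC)c(OC)c3)cc(OC)c2OC)cc1OC` gives 6700 nM, which places compound 3 second highest of the three, nearer to compound 2 than to compound 1. Within the data shown here, the one measured step, a 52-fold higher number from compound 1 to compound 2 (1.71 log units; beyond the scatter), concerns a methoxy added on an aromatic carbon of the core and does not touch the part changed here. Compound 4 `COc1cc(C(=O)c2cc(OC)c(OC)c(OC)c2)cc(NC(=O)/C=C/c2ccc(C(F)(F)F)cc2)c1OC` differs from compound 3 by 4-(trifluoromethyl)phenyl in place of 3,4-dimethoxyphenyl on a double-bonded chain carbon bound to a double-bonded chain carbon. Among the measured compounds shown here, no measured step bears directly on this exchange, so the size of the step in this assay is estimated without a close precedent; compound 4 is expected to give 3000 nM, within 800 nM to 12000 nM, a step of a 2.2-fold lower number from compound 3 to compound 4 (0.35 log units; beyond the scatter) toward a lower number.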

Compound 4, half-maximal inhibitory concentration: 3600 nM
Beside the measured number, compound 4's estimate is 1.2-fold (0.08 log units) below it; measured number inside the range.
By their numbers in this assay, from the lowest: compound 1; then compounds 4 and 3 (each within the scatter of the next); then compound 2.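

In this assay the exchange of 3,4-dimethoxyphenyl for 4-(trifluoromethyl)phenyl on a double-bonded chain carbon bound to a double-bonded chain carbon stays within the scatter (a 1.9-fold lower number from compound 3 to compound 4 (0.27 log units; within the scatter)). Among these compounds, this is the first reading at this position, and it shows that the two groups cannot be told apart here, although the entering group counts no hydrogen-bond acceptors. Nothing shown explains this result. Open, as far as these compounds go, are whether the same exchange behaves alike on the core of compound 1, and how an amine or a carboxylic acid on that phenyl ring would read.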